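The source may hold more compounds than are shown below. What is called first, only, known or untested is meant among the compounds shown, and "the series" means these compounds.

Compound 1 `COc1cc(/C=N/Nc2nc(-c3cccc(Br)c3)cs2)cc(Br)c1OC`: 56000 nM
Compound 2 `COc1cc(/C=N/Nc2nc(-c3ccc(F)c(F)c3)cs2)cc(Br)c1OC`: 21100 nM
Compound 3 `COc1ccccc1-c1csc(N/N=C/c2cc(OC)c(OC)c(Br)c2Br)n1`: 85100 nM
Compound 4 `COc1ccccc1-c1csc(N/N=C/c2cc(Br)c(OC)c(OC)c2)n1`: not yet measured

All values come from a functional assay on A549 cells (Homo sapiens) for inhibition, read by MTT assay, with a stated time of 48 h; a lower number here means a stronger inhibitor, a higher number a weaker inhibitor. Compound 3 lies within the scatter of compound 1 and has a clearly higher number than compound 2. The change to compound 4 is hydrogen in place of bromo on an aromatic carbon. Going by the values given here, no measured step covers this change. Among the compounds with values here, the only measured step, a 2.7-fold lower number from compound 1 to compound 2 (0.42 log units; beyond the scatter), is modest and sits elsewhere in the structure, so it gives only a rough scale. After the change, this part of the structure matches compound 1 and compound 2, which points to a modest drop in this assay. Expected is a 2.0-fold lower number from compound 3 to compound 4 (0.31 log units; beyond the scatter), close to the limit of the scatter. For compound 4 the estimated value is 42000 nM, with an expected range of 16000 nM to 100000 nM.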

Compound 4, half-maximal inhibitory concentration: 94900 nM
For compound 4 the middle estimate is 2.3-fold (0.35 log units) below the measured one, within the range that was stated.
By their numbers in this assay, from the lowest: compound 2; then compounds 1, 3 and 4 (each within the scatter of the next).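

In this assay hydrogen in place of bromo on this aromatic carbon, ortho to a bromo group, gives a 1.1-fold higher number from compound 3 to compound 4 (0.05 log units; within the scatter) and so leaves the reading at this position unmoved. With the rest of the structure matched, 2-methoxyphenyl in place of 3,4-difluorophenyl gives a 4.5-fold higher number from compound 2 to compound 4 (0.65 log units; beyond the scatter) while 2-methoxyphenyl in place of 3-bromophenyl gives a 1.7-fold higher number from compound 1 to compound 4 (0.23 log units; within the scatter) and only the first of these steps separates the compounds. No evidence bears on these results.

Open, going by these compounds, is whether an amine or a carboxylic acid on this carbon would shift the number, and whether the remaining bromo group can also be replaced.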